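The compounds below may be only part of what the source reports. "The series", "measured", "known", "first", "only" and "open" are said of these compounds alone.

Working notes on the series, read in an assay on isolated protein for inhibition of Fatty-acid amide hydrolase 1 (Homo sapiens); a lower number here means a stronger inhibitor, a higher number a weaker inhibitor.

Compound 1 `CCCCCCCC/C=C\CCCCCCC(=O)c1ccccc1` gives only a limit in this assay, > 100000 nM, which is a limit of the assay and not a number. Among the measured compounds shown here, compound 1 is thus the one value that sits at the limit of > 100000 nM in this assay, at which 1 of the 3 values shown sits. Compound 2 `CCCCCCCC/C=C\CCCCCCC(=O)c1nc2ccccc2o1` gives 370 nM in this assay, and compound 3 `CCCCCCCC/C=C\CCCCCCC(=O)c1ncc(-c2cccnc2)o1` gives 61 nM. For the measured compounds named here, the one measured step is an at least 270-fold lower number from compound 1 to compound 2 (2.43 log units; beyond the scatter), so the group on the carbonyl carbon governs the read-out over a wide span.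

Compound 4 `CCCCCCCC/C=C\CCCCCCCC=O` is not yet measured. It differs from compound 1 by formylmethyl in place of benzoyl on a saturated chain carbon, six bonds along the chain from a double-bonded chain carbon. Going by the values given here, no measured step covers this change; the step from compound 1 to compound 2 replaces the group on the carbonyl carbon, whereas compound 4 gives up the benzoyl altogether and keeps only a formyl carbonyl at the chain end. Since compound 1 stands at the limit, any step from it can only be downward or none at all. A modest downward step is expected, an at least 3.3-fold lower number from compound 1 to compound 4 (0.52 log units; beyond the scatter), with a fair chance that only a limit is returned again. Compound 4 is therefore estimated at 30000 nM, within 3000 nM to 150000 nM.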

Compound 4, inhibition constant: 190 nM
The estimate for compound 4 lay 160-fold (2.20 log units) above the measured number, and the stated range ends above it.
By their numbers in this assay, from the lowest: compound 3; then compounds 4 and 2 (each within the scatter of the next). At a limit, above all of these: compound 1.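

With formylmethyl in place of benzoyl on a saturated chain carbon, six bonds along the chain from a double-bonded chain carbon, this assay shows an at least 520-fold lower number from compound 1 to compound 4 (2.72 log units; beyond the scatter). The earlier step exchanged one ring for another on the carbonyl carbon, whereas this one shows that the chain ending in a plain formyl carbonyl, with no ring at all, already returns a measured number. The size of this step has only a lower bound, as compound 1 stands at a limit of the assay and not at a number: the limit of > 100000 nM in this assay, at which 1 of the 4 values shown sits.

The compounds shown leave open what a carboxylic acid, a primary alcohol or an amide at the same chain end would give. They also leave open how a shorter or a saturated chain would read with the formyl end kept.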